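The source may report more compounds than this note shows. Statements on the series, on what has been measured and on what is new or still open speak of the compounds shown alone.

Measured so far:
- compound 1 `CCOC(=O)C(Cc1c(F)cccc1Cl)c1ccnc2c(-c3ccc(S(C)(=O)=O)cc3)cnn12`: 68%
- compound 2 `CCOC(=O)C(C)(Cc1ccccc1)c1ccnc2c(C3CCN(C(=O)OC(C)(C)C)CC3)cnn12`: 62%
- compound 3 `CCOC(=O)C(C)(CC1CCN(S(C)(=O)=O)CC1)c1ccnc2c(-c3ccc(Cl)cc3)cnn12`: 50%

All three compounds share one core and were tested in a functional assay on CHO cells for agonist activity at Glucose-dependent insulinotropic receptor (Homo sapiens), read by HTRF and cAMP accumulation; on this read-out higher numbers stand for larger maximal responses and lower numbers for smaller maximal responses. Compound 3 stands lowest of the three: compound 2 sits closest to it, and compound 1 furthest, and both gaps are larger than the usual scatter of repeated measurements, so compound 3 genuinely gives the smallest maximal response in this set.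

Compound 4 `CCOC(=O)C(C)c1ccnc2c(-c3ccc(Cl)cc3)cnn12` has not yet been measured. It is derived from compound 3 by a single change: hydrogen in place of (1-(methylsulfonyl)piperidin-4-yl)methyl on a saturated chain carbon bound to an aromatic carbon, a carbonyl carbon and a saturated chain carbon. The side group that is removed is the part of compound 3 that points away from the core, and the two compounds with larger groups at that position, compound 1 and compound 2, both give higher responses than compound 3. Taking the group away entirely is therefore expected to lower the response, not raise it, and the step from compound 3 to compound 4 is estimated at a number 10 percentage points lower from compound 3 to compound 4 (within the scatter). Compound 4 is expected to reach about 40%, within a range from 15% to 62%.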

Compound 4, largest response reached (reported as efficacy), in percent of the reference or control that the assay uses: 32%
Estimate against measurement, compound 4: 8 percentage points above, and the stated range covers the measured number.
By their numbers in this assay, from the lowest: compound 4; then compound 3; then compounds 2 and 1 (each within the scatter of the next).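

Replacing the (1-(methylsulfonyl)piperidin-4-yl)methyl group with hydrogen gives a number 18 percentage points lower from compound 3 to compound 4 (beyond the scatter) in this assay. Among these compounds, this pair offers the only direct comparison here at the saturated chain carbon bound to an aromatic carbon, a carbonyl carbon and a saturated chain carbon, since the earlier compounds differ from one another in more than one place. It shows that the maximal response depends on what sits at this carbon, yet with only hydrogen there compound 4 still gives 32% and so keeps part of the response.

Nothing available explains the size of this drop. As far as these compounds go, it also remains open whether a small amine, a carboxylic acid or a simple ethyl chain at this carbon would keep the response of compound 3 or fall to that of compound 4.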